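A propanoyl for the pyrrole: cytotoxicity expected to stay low

A few compounds are considered here, and "the series" means these few. Any claim that something is new, unique, unknown or untested is made for them only; others in the source may bear on it.

The study rests on three measured compounds and one still to be measured. Compound 1 `COC(=O)c1ccc(NCc2cncn2Cc2cccc(C#N)c2)cc1-c1ccccc1` was run in a toxicity assay on NIH3T3 cells (Mus musculus) for cytotoxicity, read by resazurin assay (on this read-out lower numbers stand for an effect already at smaller amounts and higher numbers for an effect only at larger amounts of compound), where compound 1 gives > 10000 nM, a limit of the assay rather than a number. Compound 2 `c1ccc(-c2ccc(Cn3cncc3CNc3ccccc3-c3ccccc3)cc2)cc1` in this assay gives > 10000 nM, again only a limit. Compound 3 `c1ccc(-c2ccc(Cn3cncc3CNc3ccc(-c4ccc[nH]4)c(-c4ccccc4)c3)cc2)cc1` in this assay gives > 10000 nM, which is also a limit and not a measured number. Compound 3 therefore stands exactly where the other two stand, at the limit of > 10000 nM in this assay, at which 3 of the 3 values shown sit, and no value in the set reaches into the measured range.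

Compound 4 `CCC(=O)c1ccc(NCc2cncn2Cc2ccc(-c3ccccc3)cc2)cc1-c1ccccc1` has not yet been tested. Its difference from compound 3 is propanoyl in place of 1H-pyrrol-2-yl on an aromatic carbon. Among the compounds with values here, no step between measured compounds is available, so nothing in the data shows how such a change moves the read-out. Given that compound 3 sits at a limit in this assay, the step to compound 4 is expected to be none beyond the scatter, and its size is estimated as a step that the limit leaves unreadable from compound 3 to compound 4. Compound 4 is thus expected to give 15000 nM in this assay, between 6000 nM and 40000 nM, most probably reported again only as a limit.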

Compound 4, half-maximal effective concentration: > 10000 nM
Compound 4 was reported as a limit (the forecaster's own chance of this, stated with the estimate: 85%); the middle value lies beyond the limit too.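

Within the data shown here, compound 3 and compound 4 are both reported in this assay only as limits, so no step from one to the other can be read: the limit of > 10000 nM in this assay, at which 4 of the 4 values shown sit.

The compounds shown leave open at what concentration any of them would give a measured number in this assay, and whether propanoyl in place of 1H-pyrrol-2-yl moves the read-out at all.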